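The compounds below may be only part of what the source reports. "The series", "measured", "known", "first", "only" and "open" are said of these compounds alone.

Working notes on a small series read in a functional assay on PC-3 cells (Homo sapiens) for inhibition, read by sulforhodamine B assay, with a stated time of 48 h (a lower number here means a stronger inhibitor of growth, a higher number a weaker inhibitor of growth), as the only test. Compound 1 `CCOC(=O)c1nn(-c2ccccc2)c(-c2ccc(F)cc2)c1CNC(C)(C)C` gives 69300 nM; 82100 nM (2 entries) across its repeat entries. Compound 2 `CCOC(=O)c1nn(-c2ccccc2)c(-c2ccc(Cl)cc2)c1CNC(C)(C)C` gives 28600 nM; > 559000 nM (2 entries) as its entries. Compound 3 `CC(C)(C)NCc1c(C(=O)O)nn(-c2ccccc2)c1-c1ccc(F)cc1` gives > 680000 nM as its sole shown value, and this is a limit and not a number. Further entries for compound 3 carry no single number either, so it has no firm position in this assay at present.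

Compound 4 `CC(C)(C)NCc1c(C(=O)O)nn(-c2ccccc2)c1-c1ccc(Cl)cc1` is the next to be read. Its change from compound 3 is chloro in place of fluoro on an aromatic carbon and in words it is chloro in place of fluoro on an aromatic carbon, para to a large group. For the measured compounds named here, no measured step sizes this change, so none beyond the scatter is expected in this assay in either direction. The expectation rests on compound 3 and its > 680000 nM reading, which is a limit. The expected move is an at least 1.3-fold lower number from compound 3 to compound 4 (0.13 log units; that floor lies within the scatter) on this estimate and it stays within the scatter. A report of a limit alone is the likeliest outcome. For compound 4 the estimated value is 500000 nM with an expected range from 100000 nM to 800000 nM in this test.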

Compound 4, concentration for 50% growth inhibition: 145000 nM
The estimate for compound 4 lay 3.4-fold (0.54 log units) above the measured number; low and high end bracket the measured number.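

In this assay the change from 4-fluorophenyl to 4-chlorophenyl now has a size, read on the two carboxylic acids of the series: an at least 4.6-fold lower number from compound 3 to compound 4 (0.67 log units; beyond the scatter), a step beyond the scatter. Compound 3 gives > 680000 nM, which is a limit and not a number, so this step has a floor and no upper end. Compound 4 gives 145000 nM, a single number, which makes it the only carboxylic acid shown here with a firm position on this scale.

The other pairs that differ in one place, the two ethyl esters and each ester with its carboxylic acid, give no step that can be read, and whether chloro in place of fluoro has the same effect on the ethyl esters stays open, as the entries of compound 2 do not agree on one number: the several entries of compound 2 in this assay, 28600 nM; > 559000 nM (2 entries). Also open, as far as these compounds go, is how a bromo or a methoxy group in place of the chloro, or a primary amide in place of the carboxylic acid, would read in this assay on the same core.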